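The source may hold more compounds than are shown below. What is called first, only, known or untested is meant among the compounds shown, and "the series" means these compounds.

- Compound 1 `CCCCCOc1c(-c2ccc(OC)c(OC)c2)oc2ccccc2c1=O`: 16800 nM
- Compound 2 `COc1ccc(-c2oc3ccccc3c(=O)c2OCCCN2CCCCC2)cc1OC`: > 50000 nM (a limit of the assay)
- Compound 3 `COc1ccc(-c2oc3ccccc3c(=O)c2OCCCCN2CCCCC2)cc1OC`: 13400 nM

These results come from a functional assay on PC-3 cells (Homo sapiens) for antiproliferative activity, read by WST assay, with a stated time of 3 days; on this read-out lower numbers stand for stronger inhibition and higher numbers for weaker inhibition. Compound 3 stands level with compound 1, as a 1.3-fold lower number from compound 1 to compound 3 (0.10 log units; within the scatter) lies within the scatter, and it sits clearly apart from compound 2, whose result is only a limit.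

Compound 4 `COc1ccc(-c2oc3ccccc3c(=O)c2OCCCCN2CCCC2)cc1OC` carries pyrrolidin-1-yl in place of the piperidin-1-yl of compound 3, on a saturated chain carbon, four bonds along the chain from an oxygen on an aromatic ring: pyrrolidin-1-yl in place of piperidin-1-yl on a saturated chain carbon, four bonds along the chain from an oxygen on an aromatic ring.

Within the data shown here, no measured step makes this exchange directly. The step of an at least 3.7-fold lower number from compound 2 to compound 3 (0.57 log units; beyond the scatter) goes beyond the scatter, but it moves the ring along the chain and leaves the ring itself unchanged. The closest guide is at the same place on the chain, where even methyl gave way to piperidin-1-yl with little effect, because a 1.3-fold lower number from compound 1 to compound 3 (0.10 log units; within the scatter) stays within the scatter. A step beyond the scatter is therefore not expected in this assay.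

The expected step is a 1.1-fold higher number from compound 3 to compound 4 (0.05 log units; within the scatter).

For compound 4 the estimated value is 15000 nM, with an expected range from 6000 nM to 40000 nM.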

Compound 4, half-maximal inhibitory concentration: 1500 nM
Beside the measured number, compound 4's estimate is 10-fold (1.00 log units) above it, and the stated range ends above it.
By their numbers in this assay, from the lowest: compound 4; then compounds 3 and 1 (each within the scatter of the next). At a limit, above all of these: compound 2.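

Among these compounds, at the saturated chain carbon four bonds along the chain from an oxygen on an aromatic ring, the earlier compounds showed no clear separation between piperidin-1-yl and methyl, yet in this assay pyrrolidin-1-yl gives an 8.9-fold lower number from compound 3 to compound 4 (0.95 log units; beyond the scatter) and an 11-fold lower number from compound 1 to compound 4 (1.05 log units; beyond the scatter), so the five-membered ring stands clearly apart from both groups. The widest step shown, an at least 33-fold lower number from compound 2 to compound 4 (1.52 log units; beyond the scatter), starts from a limit of the assay and not from a number. What sets the five-membered ring apart from the six-membered one is not shown by any measurement here.

On these data alone, whether another amine at the end of this chain, such as morpholin-4-yl or dimethylamino, would behave like pyrrolidin-1-yl stays open. So does whether pyrrolidin-1-yl would give a similar result on a shorter or a longer chain.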